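This account rests on a few compounds, and the source may have more. Where it says the series, first, only, none or still open, it means among the compounds named here.

Measured compounds in an ADME assay on NIH3T3 cells (Mus musculus) for cytotoxicity, read by MTT assay; a higher number here means a weaker inhibitor, a lower number a stronger inhibitor:
Compound 1 `N#Cc1c(-c2ccc(O)cc2)c(C#N)c(=O)n(/N=C/c2cn(-c3ccccc3)nc2-c2ccccc2)c1N`: 110 ug/mL
Compound 2 `N#Cc1c(-c2ccc(Cl)cc2)c(C#N)c(=O)n(/N=C/c2cn(-c3ccccc3)nc2-c2ccccc2)c1N`: 64 ug/mL
Compound 3 `N#Cc1c(-c2ccc(Br)cc2)c(C#N)c(=O)n(/N=C/c2cn(-c3ccccc3)nc2-c2ccccc2)c1N`: > 200 ug/mL, a limit of the assay and not a number

Compound 3 stands only as a limit in this assay, as the limit of > 200 ug/mL in this assay, at which 1 of the 3 values shown sits, records. Compound 1 and compound 2 lie close to each other, with a 1.7-fold lower number from compound 1 to compound 2 (0.24 log units; within the scatter). The step of an at least 1.8-fold higher number from compound 1 to compound 3 (0.25 log units; that floor lies within the scatter) has a floor within the scatter, whereas an at least 3.1-fold higher number from compound 2 to compound 3 (0.49 log units; beyond the scatter) is at least modest.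

Compound 4 `N#Cc1c(-c2ccccc2C(F)(F)F)c(C#N)c(=O)n(/N=C/c2cn(-c3ccccc3)nc2-c2ccccc2)c1N` differs from compound 3 in that (2-(trifluoromethyl)phenyl in place of 4-bromophenyl on an aromatic carbon). Going by the values given here, the measured steps that bear on this place are an at least 1.8-fold higher number from compound 1 to compound 3 (0.25 log units; that floor lies within the scatter) and an at least 3.1-fold higher number from compound 2 to compound 3 (0.49 log units; beyond the scatter), both exchanges of a single group on the phenyl ring; no measured step replaces 4-bromophenyl by 2-(trifluoromethyl)phenyl, so the expectation is loose. All three measured values sit in a narrow band of weak inhibition, and the change is expected to leave compound 4 within that band, with at most a modest step downward from the limit, an at least 1.4-fold lower number from compound 3 to compound 4 (0.15 log units; that floor lies within the scatter). Compound 4 is therefore estimated at 140 ug/mL, with a likely range from 60 ug/mL to 250 ug/mL, and a fair chance that this assay again reports only a limit.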

Compound 4, half-maximal inhibitory concentration: 56 ug/mL
Beside the measured number, compound 4's estimate is 2.5-fold (0.40 log units) above it; the whole stated range lies above it.
By their numbers in this assay, from the lowest: compounds 4, 2 and 1 (each within the scatter of the next). At a limit, above all of these: compound 3.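

In this assay, placing 2-(trifluoromethyl)phenyl on this aromatic carbon gives an at least 3.5-fold lower number from compound 3 to compound 4 (0.55 log units; beyond the scatter), which shows that a change of the aryl group at this place can shift the number beyond the scatter when the starting point is 4-bromophenyl. Compound 3 remains a limit of the assay and not a number, so the size of that step is only a floor: the limit of > 200 ug/mL in this assay, at which 1 of the 4 values shown sits. Against the other two aryl groups the same replacement shows no separable change, with a 1.1-fold lower number from compound 2 to compound 4 (0.06 log units; within the scatter) and a 2.0-fold lower number from compound 1 to compound 4 (0.29 log units; within the scatter), so a substituent at the 2-position of the phenyl ring places compound 4 together with compound 1 and compound 2, leaving compound 3 alone apart from them.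

Because the substituent and its place on the phenyl ring change together in this step, the compounds shown cannot separate the two, and a pair such as 2-bromophenyl and 4-(trifluoromethyl)phenyl would be needed to do so. They also leave open how this assay responds at this carbon to a phenyl ring carrying an amine or a carboxylic acid, or to a longer chain in place of the ring.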